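Ester variation on the shared core: compound 3 to compound 4

The source may hold more compounds than are shown below. What is called first, only, known or untested is meant among the compounds shown, and "the series" means these compounds.

In a functional assay on SK-LU-1 cells (Homo sapiens) for antiproliferative activity, read by sulforhodamine B assay, with a stated time of 48 h, tested at 50 uM (a higher number here means more inhibition at the concentration tested (going by the name of the read-out), a lower number less inhibition), compound 1 `CC1=CC[C@H](C(C)C)c2cc(C)c(OC(=O)c3ccc([N+](=O)[O-])cc3)cc21` gives 47.5%, while compound 2 `CC1=CC[C@H](C(C)C)c2cc(C)c(OC(=O)c3ccc(C(F)(F)F)cc3)cc21` is reported as "not active" (no number reported) without a number. Compound 3 `CC1=CC[C@H](C(C)C)c2cc(C)c(OC(=O)c3ccc(Cl)cc3)cc21` gives 17.4% in this assay, the lowest of the two numbers available; the nearest number is that of compound 1, and the step of a number 30.1 percentage points lower from compound 1 to compound 3 (beyond the scatter) lies beyond the scatter. Compound 4 `CC1=CC[C@H](C(C)C)c2cc(C)c(OC(=O)c3cccc(C)c3)cc21` has not been measured. It differs from compound 3 by 3-methylphenyl in place of 4-chlorophenyl on a carbonyl carbon. No measured step covers a change of this kind: the only step shown, from compound 1 to compound 3, concerns a different exchange on the aromatic ring, and compound 2 supplies no number at all. The exchange is therefore judged from the spread of the three aryl esters, of which compound 1 and compound 3 give low numbers and compound 2 is reported as not active, so for compound 4 no step beyond the scatter is expected in this assay, with a number 3.4 percentage points lower from compound 3 to compound 4 (within the scatter) as the estimated movement. Compound 4 is expected to give about 14%, within 0% to 30%.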

Compound 4, a percentage reported as inhibition, at one concentration (the size of the read-out at that concentration, not a potency): "not active" (no number reported)
No number was reported for compound 4; the estimate stays without a comparison.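

For the compounds shown here, compound 4, like compound 2, is reported as not active in this assay without a number, so no step from compound 3 to compound 4 can be read. Nothing shown bears on a cause for this result. The compounds shown leave open how far 3-methylphenyl and 4-chlorophenyl separate on the shared core.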